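The compounds below may be only part of what the source reports. "The series", "measured", "known", "first", "only" and "open" are said of these compounds alone.

Measured compounds in a functional assay on cells for antagonist activity at C-C chemokine receptor type 4 (Homo sapiens), read by fluorescence and calcium flux, with stated times of 2.5 s and 45 s; a higher number here means a weaker inhibitor, a lower number a stronger inhibitor:
- compound 1 `Cc1nn([C@H](C)c2ccc(Cl)cc2Cl)c2nc(N3CC[C@H](N4CCCCC4)[C@H](C)C3)cnc12`: compound 1 gives 42 nM
- compound 2 `Cc1nn([C@H](C)c2ccc(Cl)cc2Cl)c2nc(N3CC[C@H](N4CCC[C@H]4C(=O)O)[C@H](C)C3)cnc12`: compound 2 gives 670 nM

Going by the values given here, compound 2 stands at the higher of the two numbers so far; its only neighbour is compound 1, and the single measured step, a 16-fold higher number from compound 1 to compound 2 (1.20 log units; beyond the scatter), is the whole of the ground available.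

The unmeasured compound 3 `Cc1nn([C@H](C)c2ccc(Cl)cc2Cl)c2nc(N3CC[C@H](N4CCC[C@H]4CCC#N)[C@H](C)C3)cnc12` differs from compound 2 in one place: 2-cyanoethyl in place of carboxy on a saturated ring carbon. The carboxy group that leaves is the group that entered with the step of a 16-fold higher number from compound 1 to compound 2 (1.20 log units; beyond the scatter), although that step also changed the ring, so it bears on the present change only in part. Among the compounds with values here, the 2-cyanoethyl group has no measured counterpart, so its own contribution is unknown. Removing the carboxy group is expected to move the number downward, toward compound 1, and the size of the expected step of a 5.6-fold lower number from compound 2 to compound 3 (0.75 log units; beyond the scatter) is taken as smaller than the measured step because a 16-fold higher number from compound 1 to compound 2 (1.20 log units; beyond the scatter) also contains the ring change. Compound 3 is estimated at 120 nM, with a range from 30 nM to 500 nM.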

Compound 3, half-maximal inhibitory concentration: 41 nM
Beside the measured number, compound 3's estimate is 2.9-fold (0.47 log units) above it; low and high end bracket the measured number.
By their numbers in this assay, from the lowest: compounds 3 and 1 (each within the scatter of the next); then compound 2.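

In this assay, with the five-membered non-aromatic ring kept in place, the exchange of carboxy for 2-cyanoethyl gives a 16-fold lower number from compound 2 to compound 3 (1.21 log units; beyond the scatter) and so separates the group from the ring change that was folded into the earlier step. The high number of compound 2 therefore does not belong to the five-membered ring as such, and the group on the saturated ring carbon alone is enough to produce a large step in this series. Read against the piperidin-1-yl of compound 1, the 2-(2-cyanoethyl)pyrrolidin-1-yl group gives a 1.0-fold lower number from compound 1 to compound 3 (0.01 log units; within the scatter) and shows that this position accepts a substituted five-membered ring with a chain, while nothing available here accounts for either step.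

The compounds shown leave open whether the chain or the nitrile decides the result, which a plain propyl chain or a shorter cyanomethyl group on the same ring carbon would help to separate. They also leave open whether the high number of compound 2 is tied to the free carboxylic acid, on which a methyl ester or a primary amide at that carbon would bear.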